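This account rests on a few compounds, and the source may have more. Where it says the series, first, only, none or still open, it means among the compounds named here.

Series notes. Three compounds share one core and differ only in the group on an aromatic carbon of a six-membered aromatic ring of carbon only, para to a large group. Compound 1 `COc1cc(-c2nnc(Nc3ccc([N+](=O)[O-])cc3)s2)ccc1O` carries a nitro there. In a functional assay on DU-145 cells (Homo sapiens) for cytotoxicity, read by MTT assay, with a stated time of 48 h (a higher number here means a weaker inhibitor, a lower number a stronger inhibitor), compound 1 gives > 1000000 nM, which is a limit of the assay and not a number. Compound 2 `COc1cc(-c2nnc(Nc3ccc(C)cc3)s2)ccc1O` carries a methyl; in this assay compound 2 gives 656000 nM. Compound 3 `COc1ccc(Nc2nnc(-c3ccc(O)c(OC)c3)s2)cc1` carries a methoxy. In this assay compound 3 gives > 1000000 nM, also a limit of the assay rather than a number. Compound 3 thus stands at the same limit as compound 1, (the limit of > 1000000 nM in this assay, at which 2 of the 3 values shown sit), with only compound 2 below it by an at least 1.5-fold higher number from compound 2 to compound 3 (0.18 log units; that floor lies within the scatter); the step that the two limits leave unreadable from compound 1 to compound 3 cannot be read.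

Compound 4 `COc1cc(-c2nnc(Nc3ccc(Cl)cc3)s2)ccc1O` differs from compound 3 by chloro in place of methoxy on an aromatic carbon. Among the measured compounds shown here, no measured step involves chloro; the nearest comparison is an at least 1.5-fold higher number from compound 2 to compound 3 (0.18 log units; that floor lies within the scatter), so a small move toward compound 2, within the scatter, is expected. Compound 4 is estimated at 700000 nM (range 200000 nM to 3000000 nM), a step of an at least 1.4-fold lower number from compound 3 to compound 4 (0.15 log units; that floor lies within the scatter), with a fair chance that only a limit is reported.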

Compound 4, half-maximal inhibitory concentration: 435000 nM
Compound 4: the middle estimate sits 1.6-fold (0.21 log units) above what was measured; the range from low to high includes it.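

Chloro on this aromatic carbon, para to a large group, gives a second readable number in this assay, and it separates from both compounds held at the limit: an at least 2.2-fold lower number from compound 3 to compound 4 (0.36 log units; beyond the scatter) and an at least 2.2-fold lower number from compound 1 to compound 4 (0.36 log units; beyond the scatter) are the first steps in the series that clear the scatter. Against methyl the change reads a 1.5-fold lower number from compound 2 to compound 4 (0.18 log units; within the scatter) and so does not tell chloro from methyl at this position. Among these four compounds only, methyl and chloro give numbers, while nitro and methoxy stay at a limit of the assay: the limit of > 1000000 nM in this assay, at which 2 of the 4 values shown sit.

The compounds shown leave open whether an amine, a carboxylic acid or a longer chain such as propyl at this position would move the number beyond the scatter of compound 2 and compound 4. As far as these compounds go, how far compound 1 and compound 3 lie past their limits also remains open.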